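The source may report more compounds than this note shows. Statements on the series, on what has been measured and on what is new or still open speak of the compounds shown alone.

Measured in an assay for inhibition of high affinity nerve growth factor receptor (Homo sapiens), read by HTRF, with a stated time of 30 min, in the presence of a further agent that is not named here; a higher number here means a weaker inhibitor, a lower number a stronger inhibitor:
compound 1, `Cc1cc(Nc2nc(NCc3ccc(F)cc3F)nc3ccccc23)n[nH]1`, gives 200 nM.
compound 2, `Fc1ccc(CNc2nc(Nc3cc(C4CC4)[nH]n3)c3ccccc3n2)c(F)c1`, gives 4.7 nM.
compound 3, `Cc1ccc2nc(NCc3ccc(F)cc3F)nc(Nc3cc(C)[nH]n3)c2c1`, gives 110 nM.

Compound 4, `Cc1ccc2nc(NCc3ccc(F)cc3F)nc(Nc3cc(C4CC4)[nH]n3)c2c1`, has not yet been run in this assay.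

Compound 2 differs from compound 1 by cyclopropyl in place of methyl on an aromatic carbon. That change made the step of a 43-fold lower number from compound 1 to compound 2 (1.63 log units; beyond the scatter), the one large movement seen so far in this assay.

Compound 3 differs from compound 1 by methyl in place of hydrogen on an aromatic carbon. The step was a 1.8-fold lower number from compound 1 to compound 3 (0.26 log units; within the scatter), so the core of compound 3 and the core of compound 1 are, on this evidence, interchangeable.

Compound 4 differs from compound 3 by cyclopropyl in place of methyl on an aromatic carbon. The place lines for this change and for the change from compound 1 to compound 2 agree word for word, so this is the same change made on the core of compound 3 rather than on the core of compound 1.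

If the change carries over, the step from compound 3 to compound 4 is expected to be about a 37-fold lower number from compound 3 to compound 4 (1.56 log units; beyond the scatter), resting on a 43-fold lower number from compound 1 to compound 2 (1.63 log units; beyond the scatter) together with the near-equivalence of the two cores shown by a 1.8-fold lower number from compound 1 to compound 3 (0.26 log units; within the scatter). Compound 4 is thus estimated at 3 nM, with a range from 1 nM to 12 nM.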

Compound 4, half-maximal inhibitory concentration: 57 nM
Beside the measured number, compound 4's estimate is 19-fold (1.28 log units) below it; measured number outside the range, above it.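

In this assay, cyclopropyl in place of methyl on the five-membered aromatic ring gave a 1.9-fold lower number from compound 3 to compound 4 (0.29 log units; within the scatter), so the large step seen on the core of compound 1 did not carry over to the methyl-bearing core: the same change on two cores in this assay, a 43-fold lower number (1.63 log units; beyond the scatter) from compound 1 to compound 2 and a 1.9-fold lower number (0.29 log units; within the scatter) from compound 3 to compound 4, 22-fold (1.34 log units) apart, beyond the scatter of two such steps

Read the other way, methyl in place of hydrogen on the shared core made no step beyond the scatter with the 5-methyl-1H-pyrazol-3-yl group, yet gave a 12-fold higher number from compound 2 to compound 4 (1.08 log units; beyond the scatter) with the 5-cyclopropyl-1H-pyrazol-3-yl group: the same change on two cores in this assay, a 1.8-fold lower number (0.26 log units; within the scatter) from compound 1 to compound 3 and a 12-fold higher number (1.08 log units; beyond the scatter) from compound 2 to compound 4, 22-fold (1.34 log units) apart, beyond the scatter of two such steps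

Across these four compounds the two changes therefore do not add, and the size of each depends on the other, but this does not show why, nor does it give a rule for any other core.

As far as these compounds go, whether a fluorine or a methoxy group on the shared core would also remove the cyclopropyl step stays open. So does whether an ethyl or an isopropyl group in place of cyclopropyl would behave as cyclopropyl does on either core.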